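From a Methylphenyl to a Nitrophenyl on the Shared Core

This account rests on a few compounds, and the source may have more. Where it says the series, first, only, none or still open, it means among the compounds named here.

Three compounds share a five-membered core carrying a methyl group and an acid or its ester, joined to a second ring that bears a branched thioether and a chlorinated phenyl ring. Compound 2 `Cc1ccc(-c2c(C)nn(-c3nc(-c4ccc(Cl)c(Cl)c4)c(SC(C)C)s3)c2C(=O)O)cc1` is the reference point. In a functional assay on BJAB cells (Homo sapiens) for antiproliferative activity, with a stated time of 4 days (a lower number here means that less compound is needed, a higher number that more compound is needed for the effect), compound 2 gives 3800 nM, the lowest of the three numbers shown. Compound 3 `Cc1c(-c2cc(Cl)cc(Cl)c2)c(C(=O)O)nn1-c1nc(-c2cc(Cl)ccc2F)c(SC(C)C)s1` gives 4800 nM in this assay, which lies within the usual scatter of compound 2 and so cannot be ranked against it. Compound 1 `COC(=O)c1c(Cc2ccccc2[N+](=O)[O-])c(C)nn1-c1nc(-c2ccc(Cl)c(Cl)c2)c(SC(C)C)s1` gives 93000 nM in this assay, far above both, but it differs from compound 2 in more than one place, so no single change can be read from it.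

Compound 4 `Cc1nn(-c2nc(-c3ccc(Cl)c(Cl)c3)c(SC(C)C)s2)c(C(=O)O)c1-c1ccccc1[N+](=O)[O-]` has not been measured. It differs from compound 2 in one place: 2-nitrophenyl in place of 4-methylphenyl on an aromatic carbon. Among the compounds with values here, no pair of measured compounds isolates this exchange. Compound 1 carries a nitrophenyl group together with an ester, and its high number gives pause, yet those features cannot be separated. The step from compound 2 to compound 4 in this assay is expected to be modest and toward a higher number, a 2.1-fold higher number from compound 2 to compound 4 (0.32 log units; beyond the scatter). Compound 4 is therefore expected to give about 8000 nM in this assay, within a range of 2000 nM to 40000 nM.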

Compound 4, half-maximal effective concentration: 4700 nM
For compound 4 the middle estimate is 1.7-fold (0.23 log units) above the measured one; the measured number falls inside the stated range.
By their numbers in this assay, from the lowest: compounds 2, 4 and 3 (each within the scatter of the next); then compound 1.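

In this assay, 2-nitrophenyl in place of 4-methylphenyl, on the aromatic carbon next to the ring atom that bears a carboxy group, gives a 1.2-fold higher number from compound 2 to compound 4 (0.09 log units; within the scatter), so compound 2 and compound 4 cannot be ranked against each other. This is the first pair shown that isolates a single change at this position, and it shows that the position can take a group with more heavy atoms and with two hydrogen-bond acceptors, where the 4-methylphenyl group has none, without a readable shift in the number. No measurement is available that would explain this result.

On these data alone, what remains open is how far this tolerance extends, since only these two aromatic groups can be compared at this carbon, and an unsubstituted phenyl, an aminophenyl or a group without a ring, such as a longer alkyl chain, might behave differently. As far as these compounds go, it is also open whether the same exchange would hold with a primary amide in place of the carboxy group, as every pair that can be read here keeps the acid.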